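Trifluoromethoxy for trifluoromethyl on the chalcone aryl ring

The source may hold more compounds than are shown below. What is called first, only, known or untested is meant among the compounds shown, and "the series" means these compounds.

Three compounds of the series have numbers in a functional assay on SW-620 cells (Homo sapiens) for cytotoxicity, read by MTT assay, with stated times of 4 h and 72 h, tested at 2 uM; a lower number here means a stronger inhibitor, a higher number a weaker inhibitor. Compound 1 `Cc1cc(Nc2ccc(C(=O)/C=C/c3ccccc3Cl)cc2)n2nc(SCc3nc4ccccc4[nH]3)nc2n1` gives 680 nM. Compound 2 `Cc1cc(Nc2ccc(C(=O)/C=C/c3ccc4ccccc4c3)cc2)n2nc(SCc3cccc4ccccc34)nc2n1` gives 68 nM. Compound 3 `Cc1cc(Nc2ccc(C(=O)/C=C/c3ccc(C(F)(F)F)cc3)cc2)n2nc(SCc3nc4ccccc4[nH]3)nc2n1` gives 1850 nM, the highest of the three numbers: its nearest neighbour is compound 1, with a lower number beyond the scatter, and its furthest is compound 2, with a still lower number. Going by the values given here, the one single-point step measured so far, a 2.7-fold higher number from compound 1 to compound 3 (0.43 log units; beyond the scatter), concerns the aryl ring at the end of the double-bonded chain, the same ring that is changed in the next compound.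

Compound 4 `Cc1cc(Nc2ccc(C(=O)/C=C/c3ccc(OC(F)(F)F)cc3)cc2)n2nc(SCc3nc4ccccc4[nH]3)nc2n1` differs from compound 3 in one place: trifluoromethoxy in place of trifluoromethyl on an aromatic carbon. Among the compounds with values here, no measured step in this assay compares trifluoromethoxy with trifluoromethyl; the step from compound 1 to compound 3 exchanged both the substituent and its position on that ring, so it gives only a rough sense of how much this ring can move the number. With that weak guidance, compound 4 is expected to stay near compound 3, with a step of a 1.2-fold lower number from compound 3 to compound 4 (0.09 log units; within the scatter) that is not expected to exceed the scatter. The estimate for compound 4 in this assay is 1500 nM, within a range from 600 nM to 4000 nM.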

Compound 4, half-maximal inhibitory concentration: 220 nM
Compound 4: the middle estimate sits 6.8-fold (0.83 log units) above what was measured; the measured number lies below the stated range.
By their numbers in this assay, from the lowest: compound 2; then compound 4; then compound 1; then compound 3.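

With the substituent held para to the large group, trifluoromethoxy in place of trifluoromethyl gives an 8.4-fold lower number from compound 3 to compound 4 (0.92 log units; beyond the scatter) in this assay, so this step reads the exchange of the group alone, without the change of position that clouded the earlier comparison on this ring. The exchange is small by count, one oxygen and one hydrogen-bond acceptor entering, yet the step lies beyond the scatter, so this ring position responds strongly to a minimal edit. The comparison with 2-chlorophenyl also changes direction: 4-(trifluoromethyl)phenyl gave a 2.7-fold higher number from compound 1 to compound 3 (0.43 log units; beyond the scatter), whereas 4-(trifluoromethoxy)phenyl gives a 3.1-fold lower number from compound 1 to compound 4 (0.49 log units; beyond the scatter), so a substituent at this position carries no fixed direction relative to 2-chlorophenyl across these compounds.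

As far as these compounds go, it remains open whether methoxy, an amine or a longer chain such as ethoxy at the same ring position would follow trifluoromethoxy or trifluoromethyl, and whether the step would hold with a different group on the sulfur. Nothing available on these compounds accounts for the size of the step.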